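A few compounds are considered here, and "the series" means these few. Any claim that something is new, unique, unknown or untested is made for them only; others in the source may bear on it.

Compound 1 `C=CCSc1nnc(CC)n1N1C(=O)c2ccccc2C1=O` carries an allylsulfanyl group on its core. In a functional assay on MKN-45 cells (Homo sapiens) for cytotoxicity, read by MTT assay, with a stated time of 48 h (a lower number here means a stronger inhibitor, a higher number a weaker inhibitor), compound 1 gives > 200000 nM, which is a limit of the assay. Compound 2 `CCc1nnc(SCc2ccccc2)n1N1C(=O)c2ccccc2C1=O` differs from compound 1 by phenyl in place of vinyl on a saturated chain carbon bound to a sulfur. In this assay compound 2 gives > 200000 nM, again a limit. The step that the two limits leave unreadable from compound 1 to compound 2 cannot be read, as both ends sit at the limit of > 200000 nM in this assay, at which 3 of the 3 values shown sit. Compound 3 `C=CCSc1nnc(CCC)n1N1C(=O)c2ccccc2C1=O` differs from compound 1 by methyl in place of hydrogen on a saturated chain carbon, two bonds along the chain from an aromatic carbon; that is how the two cores differ. In this assay compound 3 gives > 200000 nM, also a limit. The step that the two limits leave unreadable from compound 1 to compound 3 is likewise unreadable. Compound 4 `CCCc1nnc(SCc2ccccc2)n1N1C(=O)c2ccccc2C1=O` has not yet been measured in this assay; it differs from compound 3 by phenyl in place of vinyl on a saturated chain carbon bound to a sulfur, the same change as that from compound 1 to compound 2, made at a place described in identical words. Because all three measured values sit at the limit of > 200000 nM in this assay, at which 3 of the 3 values shown sit, there is no readable step on which to rest an expectation of a different outcome, and the step from compound 3 to compound 4 is expected to be a step that the limit leaves unreadable from compound 3 to compound 4, standing beside the unreadable earlier one. Compound 4 is estimated to give 300000 nM in this assay, with a range from 100000 nM to 1000000 nM, and most probably the assay will again report only a limit.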

Compound 4, half-maximal inhibitory concentration: > 200000 nM
Compound 4 was reported as a limit (the forecaster's own chance of this, stated with the estimate: 85%); the middle value does not contradict the limit.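

Neither the step from compound 3 to compound 4 nor the step from compound 2 to compound 4 can be read, as both ends of each step are limits and no number can be taken from them: the limit of > 200000 nM in this assay, at which 4 of the 4 values shown sit.

The compounds shown leave open how the four rank against one another in this assay, and whether either change, allyl to benzyl or the added methyl, has any effect there at all.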